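The compounds below may be only part of what the source reports. "The series", "measured", "known", "first", "only" and "open" are said of these compounds alone.

Measured compounds in a functional assay on KB cells (Homo sapiens) for cytotoxicity, read by sulforhodamine B assay; on this read-out higher numbers stand for weaker inhibition and lower numbers for stronger inhibition:
- compound 1 `COC(=O)[C@H]1C(/C=C/C(=O)c2ccc(O)cc2)=Cc2cc(OC)c(OC)cc2[C@H]1c1cc(OC)c(OC)c(OC)c1` gives 5.9 ug/mL
- compound 2 `COc1cc2c(cc1OC)[C@@H](c1cc(OC)c(OC)c(OC)c1)[C@H](C(=O)N1CCCC1)C(/C=C/C(=O)c1ccc(C3CCCCC3)cc1)=C2` gives 12.3 ug/mL

Of the two numbers, compound 2 has the higher one; compound 1 sits lower by a gap beyond the scatter. Compound 3 `COc1cc2c(cc1OC)[C@@H](c1cc(OC)c(OC)c(OC)c1)[C@H](C(=O)N1CCCC1)C(/C=C/C(=O)c1ccc(-c3ccccc3)cc1)=C2` differs from compound 2 in one place: phenyl in place of cyclohexyl on an aromatic carbon. For the measured compounds named here, no measured pair shows this exchange, so the expected step of a 1.2-fold lower number from compound 2 to compound 3 (0.09 log units; within the scatter) is none beyond the scatter, with wide uncertainty. Compound 3 is therefore estimated at 10 ug/mL, within 4 ug/mL to 25 ug/mL.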

Compound 3, half-maximal inhibitory concentration: 16.6 ug/mL
Compound 3: the middle estimate sits 1.7-fold (0.22 log units) below what was measured; measured number inside the range.
By their numbers in this assay, from the lowest: compound 1; then compounds 2 and 3 (each within the scatter of the next).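

In this assay, going from 4-cyclohexylphenyl to 4-phenylphenyl gives a 1.3-fold higher number from compound 2 to compound 3 (0.13 log units; within the scatter), so at this place, para to a large group, this read-out does not separate a non-aromatic from an aromatic six-membered carbon ring. This holds for this one pair only, with the pyrrolidine amide kept fixed. No supporting data bear on this result.

As far as these compounds go, whether an amine, a carboxylic acid or a longer alkyl chain at this place would give a step beyond the scatter stays open. Compound 1 differs from compound 2 in more than one place, so the two cannot be compared group by group.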